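The compounds below may be only part of what the source reports. "The series", "measured", "known", "first", "only" and "open" are said of these compounds alone.

Measured so far in an ADME assay on the whole organism (Mus musculus, strain C57BL6/N) for metabolic stability, read by LC-MS, with a stated time of 24 h, at a dose of 50 mg/kg by the oral route; on this read-out lower numbers stand for a shorter-lived compound and higher numbers for a longer-lived compound:
- compound 1 `CNc1cc(C)c(C(N)=O)cn1`: 1.79 h
- compound 2 `NC(=O)c1cnc2c(c1)CCN2`: 1.46 h

Only these two half-lives are available. Compound 2 at 1.46 h lies within the usual scatter of compound 1 at 1.79 h, so the data give no order between them.

The next compound is compound 3 `Cc1c(C(N)=O)cnc2c1CCN2`, which differs from compound 2 by methyl in place of hydrogen on an aromatic carbon. Within the data shown here, no measured pair differs in one place, so the data do not size this change directly. In this assay, no step beyond the scatter is expected, and no direction can be assigned with confidence. The expected 1.1-fold higher number from compound 2 to compound 3 (0.04 log units; within the scatter) is therefore small. The estimate for compound 3 is 1.6 h, with an expected range from 0.9 h to 2.9 h.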

Compound 3, half-life: 0.543 h
Compound 3: middle estimate off by 2.9-fold (0.47 log units), on the high side; the measured number lies below the stated range.
By their numbers in this assay, from the lowest: compound 3; then compounds 2 and 1 (each within the scatter of the next).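

In this assay, among these compounds, methyl in place of hydrogen on the aromatic carbon ortho to a carbamoyl group gives a 2.7-fold lower number from compound 2 to compound 3 (0.43 log units; beyond the scatter) and is the first single-place change. This position is therefore not silent on this read-out: a single added methyl, opposite the ring nitrogen, is enough to give a modest step beyond the scatter. Nothing at hand accounts for this step.

On these data alone, whether the step belongs to methyl itself or to any group at this carbon remains open; an ethyl group, a chlorine atom or a methoxy group at the same place would help separate the two. Also open is whether the same change gives a similar step on the core of compound 1, as its hydrogen counterpart is not among the compounds shown.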